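Replacing the Sulfonyl Aryl Group of Compound 3

The source may hold more compounds than are shown below. What is called first, only, known or untested is meant among the compounds shown, and "the series" means these compounds.

Compound 1 `COc1cc(-c2nc(-c3ccccc3)[nH]c2-c2ccnc(NCCCNS(=O)(=O)c3ccc(F)cc3)n2)ccc1F`: 3960 nM
Compound 2 `COc1cc(-c2nc(-c3ccccc3)[nH]c2-c2ccnc(NCCCNS(=O)(=O)c3ccc(F)cc3)n2)ccc1Cl`: 4530 nM
Compound 3 `O=S(=O)(NCCCNc1nccc(-c2[nH]c(-c3ccccc3)nc2-c2ccc(F)c(O)c2)n1)c1ccc(F)cc1`: 19200 nM

These values come from a functional assay on LOX IMVI cells (Homo sapiens) for cytotoxicity, read by MTT assay, with a stated time of 24 h; on this read-out higher numbers stand for weaker inhibition and lower numbers for stronger inhibition. Compound 3 has the highest number of the three, and so the weakest inhibition. The gaps to it are a 4.8-fold higher number from compound 1 to compound 3 (0.69 log units; beyond the scatter) and a 4.2-fold higher number from compound 2 to compound 3 (0.63 log units; beyond the scatter). The remaining pair is close together, with a 1.1-fold higher number from compound 1 to compound 2 (0.06 log units; within the scatter).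

Compound 4 `O=S(=O)(NCCCNc1nccc(-c2[nH]c(-c3ccccc3)nc2-c2ccc(F)c(O)c2)n1)c1cccc2ccccc12` differs from compound 3 at one place: naphthalen-1-yl in place of 4-fluorophenyl on a sulfonyl sulfur. In words, naphthalen-1-yl stands in place of 4-fluorophenyl on a sulfonyl sulfur.

Within the data shown here, no measured step touches that sulfonyl sulfur, so the data offer no direct guide to this change. All three steps concern the fluoro, chloro, hydroxy and methoxy groups elsewhere in the molecule, and they serve only as a scale of size. On that scale, changes stayed within the scatter or reached a modest size. Compound 3 already sits at the top of this small set, so a lower number seems somewhat more likely than a further rise, although the direction remains uncertain. The expected step is a 1.6-fold lower number from compound 3 to compound 4 (0.20 log units; within the scatter), an estimate with wide uncertainty. Compound 4 is estimated at 12000 nM, with an expected range of 4000 nM to 35000 nM.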

Compound 4, half-maximal inhibitory concentration: 3710 nM
Compound 4: the middle estimate sits 3.2-fold (0.51 log units) above what was measured; measured number below the stated range.
By their numbers in this assay, from the lowest: compounds 4, 1 and 2 (each within the scatter of the next); then compound 3.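

In this assay, placing naphthalen-1-yl in place of 4-fluorophenyl on the sulfonyl sulfur gives a 5.2-fold lower number from compound 3 to compound 4 (0.71 log units; beyond the scatter), the only measured step at this position among the compounds shown. It shows that this position is not silent: the aryl group on the sulfonyl sulfur can be changed with a modest gain in inhibition, and a second six-membered aromatic ring of carbon only is accepted here, with the fluorine gone. Nothing in the available data explains why the number falls with this change.

This single change adds a ring and removes the fluorine together, so the two cannot be separated; an unsubstituted phenyl or a naphthalen-2-yl group on the sulfonyl sulfur would help to tell which matters and whether the attachment point of the naphthalene counts. From the compounds shown here alone, it also remains open whether the same exchange would lower the number in the methoxy compounds, compound 1 and compound 2, and whether a dimethylamino group on the naphthalene or a non-aromatic group such as cyclohexyl would be accepted at this position.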